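Aryl exchange on the shared core: compound 2 to compound 3

The source may report more compounds than this note shows. Statements on the series, on what has been measured and on what is new or still open speak of the compounds shown alone.

Measured in a functional assay on B16-F0 cells (Mus musculus) for inhibition, read by CCK-8 assay, with a stated time of 48 h; a higher number here means a weaker inhibitor, a lower number a stronger inhibitor:
- compound 1 `COc1cc(-c2ccnc3cc(-c4cccc(C)c4)nn23)cc(OC)c1OC`: 2220 nM
- compound 2 `COc1cc(-c2ccnc3cc(-c4ccc5cnn(C)c5c4)nn23)cc(OC)c1OC`: 1000 nM

Compound 2 holds the lower of the two numbers. Compound 3 `COc1ccc(-c2cc3nccc(-c4cc(OC)c(OC)c(OC)c4)n3n2)cc1N` carries 3-amino-4-methoxyphenyl in place of 1-methyl-1H-indazol-6-yl on the same aromatic carbon: 3-amino-4-methoxyphenyl in place of 1-methyl-1H-indazol-6-yl on an aromatic carbon. Among the compounds with values here, the only measured step bearing on this is a 2.2-fold lower number from compound 1 to compound 2 (0.35 log units; beyond the scatter), a modest one at that carbon. Within the data shown here, it is thin support, and no measured compound carries the entering group. A somewhat larger move towards a lower number is expected in this assay, with wide uncertainty. The expected change is a 3.3-fold lower number from compound 2 to compound 3 (0.52 log units; beyond the scatter). For compound 3 the estimated value is 300 nM, with an expected range of 40 nM to 1500 nM.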

Compound 3, half-maximal inhibitory concentration: 88 nM
Beside the measured number, compound 3's estimate is 3.4-fold (0.53 log units) above it; the measured number falls inside the stated range.
By their numbers in this assay, from the lowest: compound 3; then compound 2; then compound 1.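

In this assay this aromatic carbon of the shared core proves far more sensitive than a 2.2-fold lower number from compound 1 to compound 2 (0.35 log units; beyond the scatter) indicated, with large steps both an 11-fold lower number from compound 2 to compound 3 (1.06 log units; beyond the scatter) and a 25-fold lower number from compound 1 to compound 3 (1.40 log units; beyond the scatter) on introduction of 3-amino-4-methoxyphenyl. Of the three groups compared here, this is the only one counted with a hydrogen-bond donor, although three compounds establish no link between that donor and the lower number. No measured evidence explains the gain.

The compounds shown do not separate the amino group from the methoxy group of the entering aryl. From the compounds shown here alone, whether 3-aminophenyl or 3-hydroxy-4-methoxyphenyl at this carbon would keep the number low remains open.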